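Dienone series on CNE-2 cells: two aryl head-groups compared

The source may hold more compounds than are shown below. What is called first, only, known or untested is meant among the compounds shown, and "the series" means these compounds.

Measured compounds:
compound 1, `COc1cc(C=C(C(=O)/C=C/c2cccc(OC)c2OC)C(=O)/C=C/c2cccc(OC)c2OC)cc(OC)c1O` — 300 nM
compound 2, `COc1ccc(C=C(C(=O)/C=C/c2cccc(OC)c2OC)C(=O)/C=C/c2cccc(OC)c2OC)cc1O` — 220 nM
compound 3, `COc1ccc(OC)c(/C=C/C(=O)C(=Cc2cc(OC)c(O)c(OC)c2)C(=O)/C=C/c2cc(OC)ccc2OC)c1` — 450 nM

All three were run in a functional assay on CNE-2 cells (Homo sapiens) for antiproliferative activity, read by sulforhodamine B assay, with a stated time of 48 h; on this read-out higher numbers stand for weaker inhibition and lower numbers for stronger inhibition. Compound 1 and compound 3 share the same atoms joined differently; the difference between the two cores is not broken down here. Compound 1 gives 300 nM and compound 3 gives 450 nM; the two values lie within the usual scatter of each other, so no order is read from them. Compound 2 gives 220 nM; against compound 3 this is a gap of a 1.4-fold lower number from compound 1 to compound 2 (0.13 log units; within the scatter) in the opposite direction, and the gap between compound 2 and compound 3 is the only one here that goes beyond the scatter.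

Compound 2 arises from compound 1 by 3-hydroxy-4-methoxyphenyl in place of 4-hydroxy-3,5-dimethoxyphenyl on a double-bonded chain carbon bound to a double-bonded chain carbon, and the step was a 1.4-fold lower number from compound 1 to compound 2 (0.13 log units; within the scatter). Compound 4, `COc1ccc(OC)c(/C=C/C(=O)C(=Cc2ccc(OC)c(O)c2)C(=O)/C=C/c2cc(OC)ccc2OC)c1`, arises from compound 3 by the same change, (3-hydroxy-4-methoxyphenyl in place of 4-hydroxy-3,5-dimethoxyphenyl on a double-bonded chain carbon bound to a double-bonded chain carbon); the place of the change is described in the same words in both pairs, so it is taken as the same change on a different core.

With one prior example of the change giving a step within the scatter, the expectation for compound 4 is a similarly small movement from compound 3, that is a step of about a 1.4-fold lower number from compound 3 to compound 4 (0.15 log units; within the scatter) in this assay, resting on the step of a 1.4-fold lower number from compound 1 to compound 2 (0.13 log units; within the scatter). Going by the values given here, compound 4 is thus estimated at 320 nM, with the plausible range running from 150 nM to 700 nM; the single precedent keeps the range wide.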

Compound 4, half-maximal inhibitory concentration: 730 nM
Estimate against measurement, compound 4: 2.3-fold (0.36 log units) below; the measured number lies above the stated range.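

In this assay, putting 3-hydroxy-4-methoxyphenyl in place of 4-hydroxy-3,5-dimethoxyphenyl on the core of compound 3 gives a step of a 1.6-fold higher number from compound 3 to compound 4 (0.21 log units; within the scatter). Set beside the same change on the core of compound 1, the two steps do not differ by more than two such steps normally scatter: the same change on two cores in this assay, a 1.4-fold lower number (0.13 log units; within the scatter) from compound 1 to compound 2 and a 1.6-fold higher number (0.21 log units; within the scatter) from compound 3 to compound 4, 2.2-fold (0.34 log units) apart, within the scatter of two such steps. This shows that in these two pairs the change stays within the scatter on either core, and that the pairs give no sign of the core altering what the change does; it does not show that the change carries over with a fixed size or direction, as the steps point opposite ways and neither can be told apart from repeat-measurement noise, and two pairs say nothing about other cores in the series.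

The compounds shown leave open how a head-group carrying an amine or a carboxylic acid in place of the hydroxy group would behave on either core, and whether a larger step would then appear that could be compared between cores. They also leave open how the change would behave on a third core, for example one with a longer chain between the carbonyl and the outer aryl rings.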